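Replacing Isopropyl with a Hydroxyethyl Arm

The compounds below may be only part of what the source reports. "The series", "measured", "known", "first", "only" and "open" are said of these compounds alone.

Of the compounds shown here, three have been tested in a functional assay on the whole organism (spleen, spleen) with Rattus norvegicus as the target; on this read-out lower numbers stand for an effect already at smaller amounts and higher numbers for an effect only at larger amounts of compound. Compound 1 `CCCCCCCCc1ccc(CCC(N)(CO)C(=O)O)cc1` gives only a limit here, > 10 mg/kg. Compound 2 `CCCCCCCCc1ccc(CCC(N)CO)cc1` likewise gives only a limit, > 10 mg/kg. Going by the values given here, compound 3 `CCCCCCCOc1ccc(CCC(N)(CO)C(C)C)cc1` is the single compound with a true number in this assay, 4.5 mg/kg. Among the compounds with values here, the only measured step, a step that the two limits leave unreadable from compound 1 to compound 2, cannot be read, since both of its ends sit at the limit of > 10 mg/kg in this assay, at which 2 of the 3 values shown sit. Compound 4 `CCCCCCCOc1ccc(CCC(N)(CO)CCO)cc1` differs from compound 3 by one change: 2-hydroxyethyl in place of isopropyl on a saturated chain carbon bound to an amine nitrogen and two saturated chain carbons. Within the data shown here, no measured step bears on this change, so the expectation in this assay is a step without a clear direction and within the scatter. Compound 4 is therefore expected near 5 mg/kg, with a range from 2 mg/kg to 12 mg/kg. The step this estimate implies is a 1.1-fold higher number from compound 3 to compound 4 (0.05 log units; within the scatter).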

Compound 4, dose for 50% inhibition: 0.055 mg/kg
Estimate against measurement, compound 4: 91-fold (1.96 log units) above, outside the stated range (below it).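

In this assay, 2-hydroxyethyl in place of isopropyl gives an 82-fold lower number from compound 3 to compound 4 (1.91 log units; beyond the scatter), so the group on this carbon can change the dose needed by a large margin. Going by these compounds alone, this is the first readable step at such a carbon, since the earlier step cannot be read because both of its compounds sit at a limit: the limit of > 10 mg/kg in this assay, at which 2 of the 4 values shown sit. Nothing measured here accounts for the size of this step. As far as these compounds go, it remains open whether the oxygen of the new arm is what counts. A plain propyl arm, a 2-aminoethyl arm or a longer 3-hydroxypropyl arm on this carbon could separate these possibilities.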